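Notes on the fluoro to bromo swap in compound 4

This account rests on a few compounds, and the source may have more. Where it says the series, first, only, none or still open, it means among the compounds named here.

Values in a functional assay on HT-29 cells (Homo sapiens) for antiproliferative activity, read by MTT assay, with a stated time of 72 h (on this read-out higher numbers stand for weaker inhibition and lower numbers for stronger inhibition), for the measured compounds
compound 1 (`COc1cc(-c2nccn2-c2cccc(C)c2)cc(OC)c1OC`) gives 14600 nM
compound 2 (`COc1cccc(-n2ccnc2-c2cc(OC)c(OC)c(OC)c2)c1`) gives 18900 nM
compound 3 (`COc1cc(-c2nccn2-c2ccc(F)cc2)cc(OC)c1OC`) gives 29300 nM

Compound 3 (29300 nM) sits within the scatter of both other measured compounds. Compound 4 (`COc1cc(-c2nccn2-c2ccc(Br)cc2)cc(OC)c1OC`) differs from it by one change (bromo in place of fluoro on an aromatic carbon), bromo in place of fluoro on an aromatic carbon, para to a large group. Within the data shown here, no measured step swaps one halogen for another. The nearest evidence is the exchange of the whole group on the aromatic nitrogen (a 2.0-fold higher number from compound 1 to compound 3 (0.30 log units; within the scatter) and a 1.6-fold higher number from compound 2 to compound 3 (0.19 log units; within the scatter)) and of methoxy for methyl (a 1.3-fold higher number from compound 1 to compound 2 (0.11 log units; within the scatter)), all within the scatter. No step beyond the scatter is therefore expected in this assay, and the estimated step stays small (a 1.2-fold lower number from compound 3 to compound 4 (0.09 log units; within the scatter)). Compound 4 is estimated at 24000 nM (expected range 11000 nM to 50000 nM).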

Compound 4, half-maximal inhibitory concentration: 7700 nM
Beside the measured number, compound 4's estimate is 3.1-fold (0.49 log units) above it, outside the stated range (below it).
By their numbers in this assay, from the lowest: compounds 4, 1, 2 and 3 (each within the scatter of the next, the first and the last beyond it).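

In this assay, among these compounds, the exchange of one halogen for another at this position gives a 3.8-fold lower number from compound 3 to compound 4 (0.58 log units; beyond the scatter) and so leaves the scatter, which no earlier step did. Against the other two compounds the picture is split: a 2.5-fold lower number from compound 2 to compound 4 (0.39 log units; beyond the scatter) also lies beyond the scatter, whereas a 1.9-fold lower number from compound 1 to compound 4 (0.28 log units; within the scatter) does not, so 4-bromophenyl is not separated from 3-methylphenyl. Nothing available here explains the difference between bromo and fluoro.

Going by these compounds, whether chloro or iodo at this position would track with fluoro or with bromo remains open. So does whether an amine or a nitrile there would match bromo.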